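Three thiophene-free analogues sit at the toxicity limit

This account rests on a few compounds, and the source may have more. Where it says the series, first, only, none or still open, it means among the compounds named here.

In an ADME assay on cells (Homo sapiens) for cytotoxicity, read by polymerase chain reaction, with a stated time of 3 days (on this read-out higher numbers stand for lower toxicity in this test and lower numbers for higher toxicity in this test), the three measured compounds all reach the assay's limit rather than a number. Compound 1 `Nc1nc(Cl)c(-c2cccs2)c(N[C@@H]2C[C@H](CO)[C@@H](O)[C@H]2O)n1` gives > 25000 nM, a limit. Compound 2 `Nc1nc(Cl)c(-c2nc3ccc(F)cc3s2)c(N[C@@H]2C[C@H](CO)[C@@H](O)[C@H]2O)n1` gives > 25000 nM, also a limit. Compound 3 `CNc1nc(C)c(-c2nc3ccccc3s2)c(N[C@@H]2C[C@H](CO)[C@@H](O)[C@H]2O)n1` gives > 25000 nM, again a limit, so compound 3 stands where the other two stand: the limit of > 25000 nM in this assay, at which 3 of the 3 values shown sit. Compound 4 `Cc1nc(NCCC(F)(F)F)nc(N[C@@H]2C[C@H](CO)[C@@H](O)[C@H]2O)c1-c1nc2ccccc2s1` differs from compound 3 by one change: 2,2,2-trifluoroethyl in place of hydrogen on a saturated chain carbon bound to a nitrogen on an aromatic ring. For the measured compounds named here, since every value so far is a limit, the measured compounds give no step to judge. The expected step of a number no higher from compound 3 to compound 4 (the limit leaves the size open) is none beyond the scatter, so compound 4 is estimated at 25000 nM, between 10000 nM and 60000 nM, and most likely to be reported as a limit once more.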

Compound 4, half-maximal cytotoxic concentration: 9000 nM
Compound 4: middle estimate off by 2.8-fold (0.44 log units), on the high side, and the stated range ends above it.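

In this assay, the 2,2,2-trifluoroethyl group on a saturated chain carbon bound to a nitrogen on an aromatic ring gives an at least 2.7-fold lower number from compound 3 to compound 4 (0.44 log units; beyond the scatter), and a lower number here stands for higher toxicity in this test. For the compounds shown here, this place on the shared core can therefore move the read-out, which the earlier compounds did not show. Compound 4 is the only compound shown that gives a number rather than a limit: the limit of > 25000 nM in this assay, at which 3 of the 4 values shown sit.

Going by these compounds, the full size of the step stays unknown: compound 3 gives only a limit. Also open, on these data alone, is whether a plain propyl chain on that nitrogen, without fluorine, or an amine at the chain end would read the same way.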